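The source may report more compounds than this note shows. Statements on the series, on what has been measured and on what is new or still open speak of the compounds shown alone.

In an assay on isolated protein for binding affinity to vitamin D3 receptor (Homo sapiens), read by fluorescence polarization, tested at 1 uM (a lower number here means less inhibition, a higher number more inhibition at the concentration tested (going by the name of the read-out)), compound 1 `CCN(CC)CCNC(=O)C1CC=C(C(CC)(CC)c2ccc(C#CC(C)(C)O)c(C)c2)N1CC` gives 60.2%. Compound 2 `CCN(CC)CCNC(=O)C1CC=C(C(CC)(CC)c2ccc(C#CC(C)(O)CC)c(C)c2)N1CC` gives 63.4% in this assay, and the step of a number 3.2 percentage points higher from compound 1 to compound 2 (within the scatter) means the two compounds stand within the scatter of each other, so neither can be placed above the other on these numbers.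

Compound 3 `CCCC(O)(C#Cc1ccc(C(CC)(CC)C2=CCC(C(=O)NCCN(CC)CC)N2CC)cc1C)CCC` differs from compound 2 at the same place as the earlier step: a group of 8 heavy atoms (7 carbon, 1 oxygen; no ring) in place of a group of 5 heavy atoms (4 carbon, 1 oxygen; no ring), on a triple-bonded carbon. For the measured compounds named here, the only step that bears on this change is a number 3.2 percentage points higher from compound 1 to compound 2 (within the scatter), in which a larger group at this position left this assay essentially unmoved. Going by the values given here, the data hold no step of this size at this position, so compound 3 is expected to remain near compound 2, with the expected step of a number 0.4 percentage points lower from compound 2 to compound 3 (within the scatter) lying within the scatter. Compound 3 is therefore estimated at 63%, with a range from 48% to 78%.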

Compound 3, a percentage reported as inhibition, at one concentration (the size of the read-out at that concentration, not a potency): 52.1%
The estimate for compound 3 lay 10.9 percentage points above the measured number, and the stated range covers the measured number.
By their numbers in this assay, from the lowest: compounds 3, 1 and 2 (each within the scatter of the next, the first and the last beyond it).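

In this assay the place on the triple-bonded carbon no longer looks indifferent to the group it carries: the group of 8 heavy atoms brings a change beyond the scatter against the 1-hydroxy-1-methylpropyl group of compound 2 (a number 11.3 percentage points lower from compound 2 to compound 3 (beyond the scatter)). Against the smaller group of compound 1, the same group stays within the scatter (a number 8.1 percentage points lower from compound 1 to compound 3 (within the scatter)), so the change rests on a single modest step and not on a clear trend across all three compounds. Nothing measured here accounts for this change.

Going by these compounds, it remains open whether a still longer chain on this carbon would lower the number further, and how the number would respond to a cyclohexyl ring bearing the hydroxyl or to an amine in its place. Three open-chain groups cannot show whether the count of atoms or their arrangement matters.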